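The compounds below may be only part of what the source reports. "The series", "measured", "known", "first", "only" and "open" are said of these compounds alone.

Measured so far in a functional assay (aorta) with Rattus norvegicus as the target; on this read-out lower numbers stand for an effect already at smaller amounts and higher numbers for an effect only at larger amounts of compound:
compound 1 `CNC(=N)Nc1nc(-c2ccc(OC)cc2)c(-c2ccc(OC)cc2)s1`, 1.2 uM
compound 2 `COc1ccc(-c2nc(/N=C(\N)N3CCOCC3)sc2-c2ccc(OC)cc2)cc1`, 66 uM
compound 3 `COc1ccc(-c2nc(CNC(=O)N3CCOCC3)sc2-c2ccc(OC)cc2)cc1`, 12 uM

Compound 2 has the highest number of the three, with compound 3 nearest and compound 1 furthest. Compound 4 `CCOC(=O)/C=C/c1nc(-c2ccc(OC)cc2)c(-c2ccc(OC)cc2)s1` is not yet measured; against compound 2 the change is a group of 7 heavy atoms (5 carbon, 2 oxygen; no ring) in place of a group of 9 heavy atoms (5 carbon, 3 nitrogen, 1 oxygen; one six-membered non-aromatic ring with 2 hetero atoms), on an aromatic carbon. Both known steps at this position are beyond the scatter: a 55-fold higher number from compound 1 to compound 2 (1.74 log units; beyond the scatter) and a 5.5-fold lower number from compound 2 to compound 3 (0.74 log units; beyond the scatter). Exchanging the group at this carbon therefore moves this assay strongly, and each alternative to the group in compound 2 has given a lower number. Nothing measured shares the entering group, so the direction is taken from that pattern only. For compound 4 a modest lowering is expected, a 5.5-fold lower number from compound 2 to compound 4 (0.74 log units; beyond the scatter), giving an estimated 12 uM with a range of 2 uM to 70 uM.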

Compound 4, concentration for half-maximal effect: > 100 uM
Compound 4 ended at the assay's limit (the forecaster's own chance of this, stated with the estimate: 10%); middle value at least 8.3-fold (0.92 log units) from the limit.
By their numbers in this assay, from the lowest: compound 1; then compound 3; then compound 2. At a limit, above all of these: compound 4.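

In this assay, compound 4 gives only a limit, > 100 uM. The 2-(ethoxycarbonyl)ethenyl group stands far from the groups of the two lower-numbered compounds: an at least 83-fold higher number from compound 1 to compound 4 (1.92 log units; beyond the scatter) and an at least 8.3-fold higher number from compound 3 to compound 4 (0.92 log units; beyond the scatter). So not every exchange of the group in compound 2 lowers the number, although the order against that compound stays unsettled: an at least 1.5-fold higher number from compound 2 to compound 4 (0.18 log units; that floor lies within the scatter).

Open, as far as these compounds go, is which part of 2-(ethoxycarbonyl)ethenyl goes with the higher number. Also open, from the compounds shown here alone, is where a carboxylic acid or a simple amine on this aromatic carbon would fall.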